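The source may hold more compounds than are shown below. What is called first, only, known or untested is meant among the compounds shown, and "the series" means these compounds.

The three measured compounds share one core and differ in the groups attached to it. Compound 1 `Oc1c(C(Nc2ccccn2)c2ccc(Cl)cc2)ccc2cccnc12` was tested in a functional assay on U-87MG ATCC cells for inhibition, with U-87 MG (Homo sapiens) as the target, read by MTT assay, with a stated time of 72 h; a lower number here means a stronger inhibitor, a higher number a weaker inhibitor; in that assay compound 1 gives 10600 nM. Compound 2 `Oc1cccc(C(Nc2ccccn2)c2ccc3cccnc3c2O)c1Cl` returns only a limit in this assay, > 10000 nM. The step that the limit leaves unreadable from compound 1 to compound 2 therefore cannot be sized. Compound 3 `Cc1ccnc(NC(c2cc(C)ccc2C)c2ccc3cccnc3c2O)c1` likewise returns only a limit in this assay, > 10000 nM. Among the measured compounds shown here, two of the three values thus sit together, (the limit of > 10000 nM in this assay, at which 2 of the 3 values shown sit), and none of the measured steps has a readable size. Compound 4 `Cc1ccc(C)c(C(Nc2ccccn2)c2ccc3cccnc3c2O)c1` differs from compound 3 by hydrogen in place of methyl on an aromatic carbon. For the measured compounds named here, no measured step of this kind exists among the compounds, so the expectation rests on the general level of the series, which is weak because compound 1 itself gives 10600 nM. Compound 4 is therefore expected to remain weak in this assay, with the step that the limit leaves unreadable from compound 3 to compound 4 expected to be small. The estimate for compound 4 in this assay is 15000 nM, within a range from 6000 nM to 40000 nM.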

Compound 4, half-maximal inhibitory concentration: 13800 nM
Estimate against measurement, compound 4: 1.1-fold (0.04 log units) above; measured number inside the range.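

In this assay, among the compounds shown here, the exchange of 4-chlorophenyl for 2,5-dimethylphenyl gives the first step with a readable size, a 1.3-fold higher number from compound 1 to compound 4 (0.11 log units; within the scatter), so these two groups do not separate in this assay. Compound 4, with pyridin-2-yl, gives a number where compound 3, with 4-methylpyridin-2-yl, returns only a limit. The steps to compound 4 from compound 2 and from compound 3 still cannot be read, so the methyl change has no measured size: the limit of > 10000 nM in this assay, at which 2 of the 4 values shown sit.

The compounds shown leave open whether any group at the place of that methyl, such as an amine or a carboxylic acid, would give a lower number. They also leave open whether a longer chain in place of the 2,5-dimethylphenyl group would do so.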